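The source may report more compounds than this note shows. Statements on the series, on what has been measured and on what is new or still open speak of the compounds shown alone.

In an ADME assay on GM00637 cells (Homo sapiens) for cytotoxicity, read by MTT assay, with a stated time of 72 h (on this read-out lower numbers stand for stronger inhibition and higher numbers for weaker inhibition), compound 1 (`Nc1cc2nc(-c3ccccc3)nn(-c3ccccc3)c-2cc1=O`) gives 2040 nM, compound 2 (`CNc1cc2nc(-c3ccccc3)nn(-c3ccccc3)c-2cc1=O`) gives 930 nM and compound 3 (`CCNc1cc2nc(-c3ccccc3)nn(-c3ccccc3)c-2cc1=O`) gives 240 nM. Compound 3 therefore holds the lowest of the three numbers, and both gaps to it lie beyond the scatter.

The next structure is compound 4 (`COc1cc2nc(-c3ccccc3)nn(-c3ccccc3)c-2cc1=O`), with methoxy in place of ethylamino on an aromatic carbon.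

The three measured steps all change the group on the nitrogen: a 2.2-fold lower number from compound 1 to compound 2 (0.34 log units; beyond the scatter), a 3.9-fold lower number from compound 2 to compound 3 (0.59 log units; beyond the scatter) and an 8.5-fold lower number from compound 1 to compound 3 (0.93 log units; beyond the scatter). All are modest. None replaces the nitrogen-linked group with an oxygen-linked one, so they guide the size of the new step only indirectly. Compound 3 sits at the low end of this small set at 240 nM, and the ethylamino group is lost in compound 4, so a move to a higher number is expected. Its size is expected to resemble a 3.9-fold lower number from compound 2 to compound 3 (0.59 log units; beyond the scatter), and the estimate is a 3.3-fold higher number from compound 3 to compound 4 (0.52 log units; beyond the scatter). For compound 4 the estimated value is 800 nM, with an expected range of 200 nM to 3000 nM.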

Compound 4, half-maximal inhibitory concentration: > 5000 nM
Compound 4: a limit, no number; the forecaster's own chance of this, stated with the estimate: 3%; middle value at least 6.2-fold (0.79 log units) from the limit.
By their numbers in this assay, from the lowest: compound 3; then compound 2; then compound 1. At a limit, above all of these: compound 4.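

In this assay compound 4 gives > 5000 nM, which is a limit and not a number. All three nitrogen-linked groups give lower numbers than methoxy on this aromatic carbon, as shown by an at least 20-fold higher number from compound 3 to compound 4 (1.31 log units; beyond the scatter), an at least 5.3-fold higher number from compound 2 to compound 4 (0.73 log units; beyond the scatter) and an at least 2.4-fold higher number from compound 1 to compound 4 (0.38 log units; beyond the scatter), so the oxygen-linked group falls outside the run seen across amino, methylamino and ethylamino, and even amino, the highest of those three, stays on the lower side of it. These steps fix only a minimum size for the change, not its actual size: the limit of > 5000 nM in this assay, at which 1 of the 4 values shown sits.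

Ethoxy, the oxygen-linked counterpart of ethylamino, would separate the effect of the linking atom from that of chain length. A longer chain such as propylamino would show whether the run of lower numbers continues past ethylamino.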